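This account rests on a few compounds, and the source may have more. Where it says the series, first, only, none or still open, it means among the compounds named here.

Measured so far:
compound 1 `CO[C@H]1C[C@H](O)C[C@@H](/C=C/c2ccc(Cl)cc2Cl)O1` — compound 1 gives 2% in an assay for inhibition of 3-hydroxy-3-methylglutaryl-coenzyme A reductase (Rattus norvegicus), tested at 4 ug/mL; a higher number here means a stronger effect of the compound at the concentration tested, a lower number a weaker effect
compound 2 `C[C@]1(O)CC(=O)O[C@H](/C=C/c2ccc(Cl)cc2Cl)C1` — compound 2 gives 36% in this assay
compound 3 `CC1=CC(=O)OC(/C=C/c2ccc(Cl)cc2Cl)C1` — compound 3 gives 3% in this assay

Compound 2 holds the highest of the three numbers: compound 3 comes nearest, with a number beyond the scatter lower, and compound 1 lies furthest, also beyond the scatter lower. Compound 4 `C[C@@]1(O)CC(=O)O[C@H](/C=C/c2ccc(Cl)cc2Cl)C1` remains to be measured in this assay. Its relation to compound 2: the two compounds have the same atoms and bonds and differ only in configuration as drawn: 1 of 3 stereo elements differ; a stereocentre at a saturated ring carbon is drawn R in compound 2 and S in compound 4. Within the data shown here, no pair of measured compounds here differs in one place, so no step of this kind has been observed in this assay. Among the measured compounds shown here, the expectation is nonetheless a drop beyond the scatter, since compound 2 is the only compound with a reading clearly above the others, as its 36% shows, and the change inverts one of its stereocentres. Compound 4 is estimated at 12% in this assay, within 2% to 30%, meaning an expected step of a number 24 percentage points lower from compound 2 to compound 4 (beyond the scatter).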

Compound 4, a percentage reported as inhibition, at one concentration (the size of the read-out at that concentration, not a potency): 7%
Estimate against measurement, compound 4: 5 percentage points above; the measured number falls inside the stated range.
By their numbers in this assay, from the lowest: compounds 1, 3 and 4 (each within the scatter of the next); then compound 2.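

In this assay, the series gains its first step in one place, with atoms and bonds unchanged: a number 29 percentage points lower from compound 2 to compound 4 (beyond the scatter). The inhibition read-out of compound 2 therefore depends on the R configuration drawn at this saturated ring carbon, because nothing else changes: the fact that compounds 2 and 4 differ only in the configuration as drawn. The compounds shown leave open whether a carboxylic acid or a longer chain at this stereocentre would retain the reading of compound 2, and whether the same configuration would still be favoured with either group.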